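Acyl chain extension on the shared core: compound 4

This account rests on a few compounds, and the source may have more. Where it says the series, first, only, none or still open, it means among the compounds named here.

Three compounds built on one shared core, each carrying a long acyl chain, have been measured in an ADME assay on CHO-K1 cells (Cricetulus griseus) for cytotoxicity, read by MTT assay, with a stated time of 24 h; a lower number here means a stronger inhibitor, a higher number a weaker inhibitor. Compound 1 `CCCCCCCCCCCC(=O)Nc1nnc(S[C@@H]2O[C@H](COC(C)=O)[C@H](OC(C)=O)[C@H](OC(C)=O)[C@H]2OC(C)=O)s1` gives 27700 nM. Compound 2 `CCCCCCCCCCCCCC(=O)Nc1nnc(S[C@@H]2O[C@H](COC(C)=O)[C@H](OC(C)=O)[C@H](OC(C)=O)[C@H]2OC(C)=O)s1` gives 16300 nM. Compound 3 `CCCCCCCC/C=C\CCCCCCCC(=O)Nc1nnc(S[C@@H]2O[C@H](COC(C)=O)[C@H](OC(C)=O)[C@H](OC(C)=O)[C@H]2OC(C)=O)s1` gives 26300 nM. Compound 2 is not separated from either companion: a 1.7-fold lower number from compound 1 to compound 2 (0.23 log units; within the scatter), and a 1.6-fold higher number from compound 2 to compound 3 (0.21 log units; within the scatter), both within the scatter; the third pairing, a 1.1-fold lower number from compound 1 to compound 3 (0.02 log units; within the scatter), is within the scatter as well, so the three numbers form one group.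

Compound 4 `CCCCCCCC/C=C\CCCCCCCCCCCC(=O)Nc1nnc(S[C@@H]2O[C@H](COC(C)=O)[C@H](OC(C)=O)[C@H](OC(C)=O)[C@H]2OC(C)=O)s1` has not yet been measured. Relative to compound 2 the change is dec-1-en-1-yl in place of ethyl on a saturated chain carbon, ten or more bonds along the chain from a carbonyl carbon. Going by the values given here, two measured steps bear on it. Lengthening the saturated chain by ethyl, a 1.7-fold lower number from compound 1 to compound 2 (0.23 log units; within the scatter), did not leave the scatter. Bringing in dec-1-en-1-yl for a saturated tail at the shorter distance from the carbonyl, a 1.6-fold higher number from compound 2 to compound 3 (0.21 log units; within the scatter), did not leave it either. Among the compounds with values here, nothing among the measured pairs suggests that the same group set further out would act differently. The step in this assay is therefore expected to stay within the scatter: a 1.2-fold higher number from compound 2 to compound 4 (0.09 log units; within the scatter). Compound 4 is estimated at 20000 nM, with a range from 8000 nM to 50000 nM.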

Compound 4, half-maximal inhibitory concentration: 25200 nM
Compound 4: middle estimate off by 1.3-fold (0.10 log units), on the low side; low and high end bracket the measured number.
By their numbers in this assay, from the lowest: compounds 2, 4, 3 and 1 (each within the scatter of the next).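

In this assay the change of dec-1-en-1-yl in place of ethyl, on a saturated chain carbon, gives a 1.5-fold higher number from compound 2 to compound 4 (0.19 log units; within the scatter) and so extends the earlier picture to this further place on the chain. The same group read as dec-1-en-1-yl in place of hydrogen gives a 1.1-fold lower number from compound 1 to compound 4 (0.04 log units; within the scatter) and leaves all four compounds in one group, so neither the double bond at this place nor the larger tail separates compound 4 from the saturated compound 1 or compound 2. No measurement bearing on the cause of this result is available.

All the chains shown are long and purely carbon tails on the shared core, so the reading says nothing yet about an amine or a carboxylic acid carried on the chain in place of dec-1-en-1-yl. As far as these compounds go, a much shorter acyl chain such as acetyl, and a change to the acetyl esters on the core, also remain open, and either would show whether any change can leave the scatter in this assay at all.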